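A few compounds are considered here, and "the series" means these few. Any claim that something is new, unique, unknown or untested is made for them only; others in the source may bear on it.

Measured in a functional assay on DLD-1 cells (Homo sapiens) for antiproliferative activity, read by CellTiter-Glo, with a stated time of 72 h; on this read-out lower numbers stand for stronger inhibition and higher numbers for weaker inhibition:
- compound 1 `COc1ccccc1-c1cccc(S(=O)(=O)N2CCC(N3CCC(C)CC3)CC2)c1`: 21 nM
- compound 2 `CC(=O)Nc1ccc(S(=O)(=O)N2CCC(N3CCC(C)CC3)CC2)c2ccccc12`: 1100 nM

Of these two, compound 1 holds the lower number, with compound 2 beyond the scatter above it. Next is compound 3 `CC1CCN(C2CCN(S(=O)(=O)c3cccc(-c4ccc(F)cc4)c3)CC2)CC1`, with 4-fluorophenyl in place of 2-methoxyphenyl on an aromatic carbon, meta to a large group: 4-fluorophenyl in place of 2-methoxyphenyl on an aromatic carbon. Among the compounds with values here, no measured pair shows this kind of swap, so the expectation is loose. In this assay a modest step towards a higher number is expected, though one within the scatter remains possible. The estimated step is a 1.9-fold higher number from compound 1 to compound 3 (0.28 log units; within the scatter). For compound 3 the expected value is 40 nM, with an estimated range of 12 nM to 150 nM.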

Compound 3, half-maximal inhibitory concentration: 12 nM
Estimate against measurement, compound 3: 3.3-fold (0.52 log units) above; low and high end bracket the measured number.
By their numbers in this assay, from the lowest: compounds 3 and 1 (each within the scatter of the next); then compound 2.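

In this assay, 4-fluorophenyl in place of 2-methoxyphenyl on this aromatic carbon gives a 1.8-fold lower number from compound 1 to compound 3 (0.24 log units; within the scatter). This position therefore takes a second aryl group with no clear change in the read-out, and the hydrogen-bond acceptor counted in 2-methoxyphenyl is not required for a value in this range. No available evidence accounts for the two groups reading alike. The compounds shown leave open how plain phenyl reads at this place, which would separate the fluorine from the methoxy group. From the compounds shown here alone, whether a non-aromatic group, such as an amine or a carboxylic acid, holds the activity here also remains open.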